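Methoxyphenyl for fluorophenyl on the styryl arm

This account rests on a few compounds, and the source may have more. Where it says the series, first, only, none or still open, it means among the compounds named here.

Measured in an assay on cells for inhibition of Ectonucleotide pyrophosphatase/phosphodiesterase family member 1 (Homo sapiens), with a stated time of 60 min; on this read-out higher numbers stand for weaker inhibition and lower numbers for stronger inhibition:
compound 1 `COc1cc2nc(/C=C/c3ccccc3)nc(N3CCC(CCNS(N)(=O)=O)CC3)c2cc1OC`: 1840 nM
compound 2 `COc1cc2nc(/C=C/c3ccncc3)nc(N3CCC(CCNS(N)(=O)=O)CC3)c2cc1OC`: 218 nM
compound 3 `COc1cc2nc(/C=C/c3cccc(F)c3)nc(N3CCC(CCNS(N)(=O)=O)CC3)c2cc1OC`: 3580 nM

Compound 3 gives the highest number of the three. Its nearest neighbour is compound 1, with a 1.9-fold higher number from compound 1 to compound 3 (0.29 log units; within the scatter), a step within the scatter; the gap to compound 2 is wide, a 16-fold higher number from compound 2 to compound 3 (1.22 log units; beyond the scatter). For the measured compounds named here, the only change in the set that has moved this assay beyond the scatter is an 8.4-fold lower number from compound 1 to compound 2 (0.93 log units; beyond the scatter).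

Compound 4 `COc1ccc(/C=C/c2nc(N3CCC(CCNS(N)(=O)=O)CC3)c3cc(OC)c(OC)cc3n2)cc1` differs from compound 3 by 4-methoxyphenyl in place of 3-fluorophenyl on a double-bonded chain carbon bound to a double-bonded chain carbon. Going by the values given here, two measured steps bear on it: the fluoro step from compound 1 to compound 3, which stayed within the scatter, and the pyridin-4-yl step, which was large. The entering group brings an acceptor that the leaving group lacks, on an all-carbon ring as in compound 1. A downward step is therefore expected, of a size between those two cases, putting compound 4 near compound 1 or somewhat stronger. The expected step is a 3.0-fold lower number from compound 3 to compound 4 (0.47 log units; beyond the scatter). Compound 4 is estimated at 1200 nM, with a range of 400 nM to 4000 nM.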

Compound 4, inhibition constant: 231 nM
Estimate against measurement, compound 4: 5.2-fold (0.72 log units) above; the measured number lies below the stated range.
By their numbers in this assay, from the lowest: compounds 2 and 4 (each within the scatter of the next); then compounds 1 and 3 (each within the scatter of the next).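

Pyridin-4-yl is no longer the only group on the double-bonded chain carbon to move this assay beyond the scatter: 4-methoxyphenyl in place of 3-fluorophenyl gives a large step (a 15-fold lower number from compound 3 to compound 4 (1.19 log units; beyond the scatter)), and methoxy in place of hydrogen on the aromatic carbon of the phenyl ring gives a modest one (an 8.0-fold lower number from compound 1 to compound 4 (0.90 log units; beyond the scatter)). An all-carbon ring at this place therefore does not by itself keep the number high, and the two groups are not separated (a 1.1-fold higher number from compound 2 to compound 4 (0.03 log units; within the scatter)). No measurement here accounts for this match or for the gap to 3-fluorophenyl.

Open, on these data alone, is whether the step follows methoxy itself or its place on the ring, which 3-methoxyphenyl would test. Also open, as far as these compounds go, is whether 4-hydroxyphenyl or 4-(dimethylamino)phenyl would stand with compound 4 or with compound 1.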